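Swapping a Furanylmethyl for an Oxanyl Ring

The compounds below may be only part of what the source reports. "The series", "measured", "known", "first", "only" and "open" are said of these compounds alone.

Compound 3 `N=c1c2c(-c3ccccc3)cn(Cc3ccccc3)c2ncn1Cc1ccco1` carries a (furan-2-yl)methyl group on an aromatic nitrogen of the shared core. In an ADME assay for permeability, using PAMPA, with a stated time of 30 min, at pH 7.4 (on this read-out lower numbers stand for lower permeability and higher numbers for higher permeability), compound 3 gives 1740 10^-6 cm/s, the top of the three numbers shown, though compound 1 `N=c1c2c(-c3ccccc3)cn(Cc3ccccc3)c2ncn1CCO`, which gives 1270 10^-6 cm/s, lies within the scatter of it. Compound 2 `COc1ccc(-c2c(-c3ccc(OC)cc3)n(Cc3ccccc3)c3ncn([C@H]4CC[C@H](O)CC4)c(=N)c23)cc1`, with a differently substituted core, gives 196 10^-6 cm/s. Among the compounds with values here, the only one-place step measured runs a 1.4-fold higher number from compound 1 to compound 3 (0.14 log units; within the scatter), so exchanging the group on that nitrogen left the number essentially unchanged. Compound 4 `N=c1c2c(-c3ccccc3)cn(Cc3ccccc3)c2ncn1C1CCOCC1` arises from compound 3 by oxan-4-yl in place of (furan-2-yl)methyl on an aromatic nitrogen. On that basis compound 4 is expected to move little, a 1.3-fold lower number from compound 3 to compound 4 (0.13 log units; within the scatter). Compound 4 is estimated at 1300 10^-6 cm/s, with a range from 600 10^-6 cm/s to 2500 10^-6 cm/s.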

Compound 4, apparent permeability: 1730 10^-6 cm/s
Beside the measured number, compound 4's estimate is 1.3-fold (0.12 log units) below it; the measured number falls inside the stated range.
By their numbers in this assay, from the lowest: compound 2; then compounds 1, 4 and 3 (each within the scatter of the next).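

Placing oxan-4-yl in this assay where (furan-2-yl)methyl stood gives a 1.0-fold lower number from compound 3 to compound 4 (0.00 log units; within the scatter), so exchanging a five-membered aromatic ring for a six-membered non-aromatic ring on this aromatic nitrogen leaves the number unchanged here. Oxan-4-yl in place of 2-hydroxyethyl gives a 1.4-fold higher number from compound 1 to compound 4 (0.13 log units; within the scatter), so compounds 1, 3 and 4 all lie within the scatter of one another. No evidence is at hand on what lies behind this sameness. Still open, going by these compounds, is whether an amine or a carboxylic acid on this nitrogen would keep the number in this range.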